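Cycloheptyl gives way to 4-ethylcyclohexyl in compound 3

This account rests on a few compounds, and the source may have more. Where it says the series, first, only, none or still open, it means among the compounds named here.

Compound 1 `CCC(C)C(=O)N1CCC(NC(=O)Nc2ccc(C(F)(C(F)(F)F)C(F)(F)F)cc2)CC1`: 754 ng.h/mL
Compound 2 `CCC(C)C(=O)N1CCC(NC(=O)NC2CCCCCC2)CC1`: 24.3 ng.h/mL

In an ADME assay on the whole organism (plasma, strain Swiss Webster) for pharmacokinetics, with Mus musculus as the target, using cassette dosing, at a dose of 0.3 mg/kg by the oral route (on this read-out lower numbers stand for lower exposure and higher numbers for higher exposure at the dose given), compound 2 gives 24.3 ng.h/mL, the lower of the two numbers, and compound 1 gives 754 ng.h/mL, a gap well beyond the scatter. The next compound to be measured, compound 3 `CCC(C)C(=O)N1CCC(NC(=O)N[C@H]2CC[C@H](CC)CC2)CC1`, departs from compound 2 at a single place: 4-ethylcyclohexyl in place of cycloheptyl on an amide-type nitrogen. Both the group that leaves and the group that enters are non-aromatic rings of carbon only, with no net charge. For the measured compounds named here, no measured pair of compounds shows what a change of this kind does to exposure, so the expectation is a cautious one, and it starts from compound 2 at 24.3 ng.h/mL. The estimated step of a 1.6-fold higher number from compound 2 to compound 3 (0.22 log units; within the scatter) is expected to be small, upward if anything, and not clearly beyond the scatter. For compound 3 the expected value is 40 ng.h/mL, with an estimated range from 12 ng.h/mL to 140 ng.h/mL.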

Compound 3, area under the concentration-time curve in the Mus musculus assay: 12.5 ng.h/mL
Estimate against measurement, compound 3: 3.2-fold (0.51 log units) above; the measured number falls inside the stated range.
By their numbers in the Mus musculus assay, from the lowest: compounds 3 and 2 (each within the scatter of the next); then compound 1.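

In the Mus musculus assay, the exchange of a seven-membered non-aromatic carbon ring for 4-ethylcyclohexyl on the amide-type nitrogen gives a 1.9-fold lower number from compound 2 to compound 3 (0.29 log units; within the scatter), the first step at this position in the compounds shown. At this oral dose, therefore, exposure does not separate these two non-aromatic rings of carbon only, even though the entering group adds a carbon and two defined stereocentres, and compound 2 and compound 3 stand together as a pair, while compound 1 gives 754 ng.h/mL. Nothing shown gives a measured reason for this outcome or says what governs exposure in this series.

For the compounds shown here, in a physicochemical assay for lipophilicity, using the shake flask method (on this read-out lower numbers stand for lower lipophilicity and higher numbers for higher lipophilicity), compound 2 gives "not determined" (no result reported) and compound 3 gives "not determined" (no result reported), so no step in lipophilicity can be read and the pair's similar exposure cannot be set against that property. Also open, going by these compounds, is whether the other arrangement of the two stereocentres in 4-ethylcyclohexyl, a longer chain in place of its ethyl, or an amine or a hydroxyl group on that ring would give a number that stands clearly apart from those of compound 2 and compound 3.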